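The source may hold more compounds than are shown below. What is called first, only, known or untested is meant among the compounds shown, and "the series" means these compounds.

Of the compounds shown here, three built on one shared core have been tested in an assay on a protein complex for inhibition of ubiquitin carboxyl-terminal hydrolase 1/WD repeat-containing protein 48 (Homo sapiens), read by fluorescence; a higher number here means a weaker inhibitor, a lower number a stronger inhibitor. Compound 1 `FC(F)(F)c1ccccc1-c1nc(NCc2ccc(Cl)c(Cl)c2)c2ccccc2n1` gives 10400 nM, compound 2 `FC(F)(F)c1ccccc1-c1nc(NCC#Cc2cccnc2)c2ccccc2n1` gives 8900 nM, and compound 3 `FC(F)(F)c1ccccc1-c1nc(NCc2ccc(-c3ccccc3)cc2)c2ccccc2n1` gives 3700 nM. Compound 3 stands at the lowest number of the three, and its gaps to compound 2 and to compound 1 both lie beyond the scatter. Going by the values given here, the only step between neighbouring structures, a 1.2-fold lower number from compound 1 to compound 2 (0.07 log units; within the scatter), lies within the scatter and concerns the group on the saturated chain carbon bound to the ring nitrogen, so it says nothing about the change considered here.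

Compound 4 `FC(F)(F)c1ccccc1-c1nc(NCc2ccc(C3CCCCC3)cc2)c2ccccc2n1` differs from compound 3 by cyclohexyl in place of phenyl on an aromatic carbon. Among the compounds with values here, no measured pair exchanges an aromatic ring for a non-aromatic one at this place, so the expectation rests on compound 3 alone, which gives 3700 nM; a step of modest size is expected, with a slightly higher number somewhat more likely than a lower one. Compound 4 is therefore estimated at 4500 nM, between 1500 nM and 14000 nM, an expected step of a 1.2-fold higher number from compound 3 to compound 4 (0.09 log units; within the scatter).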

Compound 4, half-maximal inhibitory concentration: 9800 nM
For compound 4 the middle estimate is 2.2-fold (0.34 log units) below the measured one; the range from low to high includes it.
By their numbers in this assay, from the lowest: compound 3; then compounds 2, 4 and 1 (each within the scatter of the next).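

In this assay, going by these compounds alone, cyclohexyl in place of phenyl on this aromatic carbon gives a 2.6-fold higher number from compound 3 to compound 4 (0.42 log units; beyond the scatter) and is the first measured exchange at this place. The two groups have the same count of heavy atoms and neither has a hydrogen-bond donor or acceptor, so the step shows that the number can move beyond the scatter when only the aromatic ring gives way to a non-aromatic one of the same size. No measured evidence bears on why this exchange gives a higher number.

On these data alone, it remains open whether a pyridine ring, a piperidine ring or a morpholine ring at this place would give a number closer to that of phenyl or of cyclohexyl. As far as these compounds go, how an open chain such as tert-butyl or a small group such as methyl would compare also stays unknown.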